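A Ring Replaces a Chain at the Aromatic Carbon

A few compounds are considered here, and "the series" means these few. Any claim that something is new, unique, unknown or untested is made for them only; others in the source may bear on it.

Three compounds have been measured in a functional assay on CHO cells for agonist activity at Alpha-1A adrenergic receptor (Homo sapiens), read by FLIPR and calcium flux; a lower number here means that less compound is needed, a higher number that more compound is needed for the effect:
Compound 1, `CCCS(=O)(=O)Nc1cccc2c1CCC2c1ncc[nH]1`, gives 1340 nM.
Compound 2, `CS(=O)(=O)Nc1cccc2c1CCC2c1ncc[nH]1`, gives 70 nM.
Compound 3, `CCS(=O)(=O)Nc1cccc2c1CCC2c1ncc[nH]1`, gives 32 nM.

Compound 3 has the lowest number of the three. Its nearest neighbour is compound 2, with a 2.2-fold lower number from compound 2 to compound 3 (0.34 log units; beyond the scatter); the furthest is compound 1, with a 42-fold lower number from compound 1 to compound 3 (1.62 log units; beyond the scatter). The remaining step, a 19-fold lower number from compound 1 to compound 2 (1.28 log units; beyond the scatter), completes the set. All three steps change only the length of the chain on the sulfonyl sulfur, and each of them moved the number beyond the scatter.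

Compound 4, `Cn1cc(-c2cccc3c2CCC3c2ncc[nH]2)cn1`, is not yet measured. It differs from compound 3 by 1-methyl-1H-pyrazol-4-yl in place of (ethylsulfonyl)amino on an aromatic carbon. This is a different kind of change: the whole (ethylsulfonyl)amino group, with its one hydrogen-bond donor, leaves, and an aromatic ring enters in its place. Among the compounds with values here, none of the measured steps tests such a swap, since each of them kept the sulfonyl group and varied only its chain. The data therefore give no direct guide, and the estimate must be wide. Because removing even a methyl from that chain was enough for a 2.2-fold lower number from compound 2 to compound 3 (0.34 log units; beyond the scatter), the group appears sensitive to its shape, so a higher number is expected for compound 4, and the step is estimated at a 9.4-fold higher number from compound 3 to compound 4 (0.97 log units; beyond the scatter). Compound 4 is expected to give about 300 nM, within a range from 30 nM to 3000 nM.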

Compound 4, half-maximal effective concentration: > 2900 nM
Compound 4: only a limit was reported; the forecaster's own chance of this, stated with the estimate: 10%; middle value at least 9.6-fold (0.98 log units) from the limit.
By their numbers in this assay, from the lowest: compound 3; then compound 2; then compound 1. At a limit, above all of these: compound 4.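

In this assay, compound 4 gave only a limit of the assay, not a number: the limit of > 2900 nM in this assay, at which 1 of the 4 values shown sits. The earlier compounds shown here showed that the number shifts with the chain on the sulfonyl sulfur, whereas replacing the whole group on this aromatic carbon with 1-methyl-1H-pyrazol-4-yl gives an at least 90-fold higher number from compound 3 to compound 4 (1.95 log units; beyond the scatter), and the same replacement gives an at least 41-fold higher number from compound 2 to compound 4 (1.61 log units; beyond the scatter) and an at least 2.1-fold higher number from compound 1 to compound 4 (0.33 log units; beyond the scatter), so each of the three sulfonyl compounds lies lower than compound 4, even the one with the propyl chain. The change keeps the count of heavy atoms and hydrogen-bond acceptors, so matching those counts did not preserve the low numbers; what does differ is that the one hydrogen-bond donor is lost and an aromatic ring enters.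

These compounds cannot separate the loss of that donor from the loss of the sulfonyl group or the arrival of the ring. An acetylamino group, which keeps the hydrogen on the nitrogen without the sulfonyl group, or a methylsulfonyl group attached directly to the aromatic carbon, which keeps the sulfonyl group without that nitrogen, would begin to pull these apart.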